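From methylsulfonyl to ethylsulfonyl: compound 3 and compound 4

The source may report more compounds than this note shows. Statements on the series, on what has been measured and on what is new or still open speak of the compounds shown alone.

The measured compounds share one core and differ in the group on the amide-type nitrogen. In an ADME assay on MT4 cells (Homo sapiens) for cytotoxicity, read by MTT assay, with a stated time of 5 days (a higher number here means that more compound is tolerated, a lower number that less compound is tolerated), compound 1 `Cc1cc(C)cc(S(=O)(=O)c2c(C(=O)N[C@H]3CCN(Cc4cccnc4)C3)[nH]c3ccc(Cl)cc23)c1` gives 22800 nM. Compound 2 `Cc1cc(C)cc(S(=O)(=O)c2c(C(=O)NC3CN(Cc4ccccc4F)C3)[nH]c3ccc(Cl)cc23)c1` gives > 238000 nM, which is a limit of the assay. Compound 3 `Cc1cc(C)cc(S(=O)(=O)c2c(C(=O)NS(C)(=O)=O)[nH]c3ccc(Cl)cc23)c1`, with methylsulfonyl on that nitrogen, gives 40200 nM. Among the compounds with values here, its number lies within the scatter of the only other measured number: a 1.8-fold higher number from compound 1 to compound 3 (0.25 log units; within the scatter). The measured limit stands apart from both: an at least 10-fold higher number from compound 1 to compound 2 (1.01 log units; beyond the scatter), and an at least 5.9-fold lower number from compound 2 to compound 3 (0.77 log units; beyond the scatter).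

Compound 4 `CCS(=O)(=O)NC(=O)c1[nH]c2ccc(Cl)cc2c1S(=O)(=O)c1cc(C)cc(C)c1` differs from compound 3 by methyl in place of hydrogen on a saturated chain carbon bound to a sulfonyl sulfur, turning methylsulfonyl into ethylsulfonyl. Within the data shown here, no measured step covers so small a change. All three measured steps replace the whole group on the amide-type nitrogen, and the two involving compound 2 are the only ones beyond the scatter. With compound 3 at 40200 nM as the starting point, no step beyond the scatter is expected in this assay. The expected step is a 1.0-fold higher number from compound 3 to compound 4 (0.02 log units; within the scatter). Compound 4 is estimated at 42000 nM, with an expected range of 18000 nM to 95000 nM.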

Compound 4, half-maximal cytotoxic concentration: > 283000 nM
Compound 4: only a limit was reported; the forecaster's own chance of this, stated with the estimate: 12%; middle value at least 6.7-fold (0.82 log units) away from the limit.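

Notes on the sulfonyl position: in this assay, methyl in place of hydrogen on a saturated chain carbon bound to a sulfonyl sulfur is the smallest change among the steps shown, yet it moves the number beyond the scatter: an at least 7.0-fold higher number from compound 3 to compound 4 (0.84 log units; beyond the scatter). The earlier replacement of the whole group on the amide-type nitrogen by methylsulfonyl stayed within the scatter (a 1.8-fold higher number from compound 1 to compound 3 (0.25 log units; within the scatter)), whereas ethylsulfonyl in that same replacement gives a large step: an at least 12-fold higher number from compound 1 to compound 4 (1.09 log units; beyond the scatter). The sulfonyl series is therefore sensitive at this chain carbon, and compound 4 is reported only as a limit of the assay, not as a number: the limit of > 283000 nM in this assay, at which 1 of the 4 values shown sits.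

Going by these compounds, the step between compound 2 and compound 4 cannot be read, so the order of the azetidine-bearing group and ethylsulfonyl stays open, as does how far the number of compound 4 actually lies past its limit. Also open, on these data alone, is whether the higher number continues with a longer chain such as propylsulfonyl, or holds when the ethyl chain ends in an amine or a carboxylic acid.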